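The source may hold more compounds than are shown below. What is called first, only, known or untested is meant among the compounds shown, and "the series" means these compounds.

Measured compounds:
Compound 1, `S=C(Nc1ccccc1)N1N=C(c2ccccc2)CC1c1ccc2c(c1)OCCO2`, gives 6630 nM in a functional assay on HT-29 cells (Homo sapiens) for antiproliferative activity, read by MTT assay, with a stated time of 48 h; on this read-out higher numbers stand for weaker inhibition of growth and lower numbers for stronger inhibition of growth.
Compound 2, `S=C(Nc1ccccc1)N1N=C(c2ccc(Cl)cc2)CC1c1ccc2c(c1)OCCO2`, gives 187000 nM in this assay.
Compound 3, `Cc1ccc(C2=NN(C(=S)Nc3ccccc3)C(c3ccc4c(c3)OCCO4)C2)cc1C`, gives 133000 nM in this assay.

Compound 3 holds the second highest of the three numbers in this assay. Its nearest neighbour is compound 2, as shown by a 1.4-fold lower number from compound 2 to compound 3 (0.15 log units; within the scatter); its furthest is compound 1, as shown by a 20-fold higher number from compound 1 to compound 3 (1.30 log units; beyond the scatter).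

Compound 4, `S=C(Nc1ccccc1)N1N=C(c2cccs2)CC1c1ccc2c(c1)OCCO2`, is not yet measured. The change from compound 3 is thiophen-2-yl in place of 3,4-dimethylphenyl on a carbon with a double bond to nitrogen. The measured steps at the same carbon are a 20-fold higher number from compound 1 to compound 3 (1.30 log units; beyond the scatter) and a 1.4-fold lower number from compound 2 to compound 3 (0.15 log units; within the scatter); the remaining step, a 28-fold higher number from compound 1 to compound 2 (1.45 log units; beyond the scatter), concerns a substituent on that aromatic ring. Across these three compounds the unsubstituted phenyl of compound 1 stands with the lowest number and both substituted phenyls with high numbers. Thiophen-2-yl carries no substituent, but no measured step here covers a five-membered heteroaromatic ring at this position, so the expectation is uncertain. Compound 4 is expected to lie between compound 1 and compound 3, nearer the latter. Compound 4 is estimated at 40000 nM in this assay, range 6000 nM to 180000 nM. The expected step is a 3.3-fold lower number from compound 3 to compound 4 (0.52 log units; beyond the scatter).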

Compound 4, concentration for 50% growth inhibition: 188000 nM
Beside the measured number, compound 4's estimate is 4.7-fold (0.67 log units) below it, and the stated range ends below it.
By their numbers in this assay, from the lowest: compound 1; then compounds 3, 2 and 4 (each within the scatter of the next).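

In this assay thiophen-2-yl does not stay with the unsubstituted phenyl of compound 1 (a 28-fold higher number from compound 1 to compound 4 (1.45 log units; beyond the scatter)), a step of the same size as the one made by adding chloro to that phenyl. Compound 4 instead falls with the two substituted phenyls (a 1.4-fold higher number from compound 3 to compound 4 (0.15 log units; within the scatter); a 1.0-fold higher number from compound 2 to compound 4 (0.00 log units; within the scatter)), so the lack of a substituent on the ring does not by itself go with the lower number, and among the four groups shown at this carbon only the phenyl of compound 1 stands apart. No measured evidence bears on why this is so.

From the compounds shown here alone, it remains open whether any other group here keeps the lower number of compound 1, such as fluoro or methoxy on the phenyl, a furan-2-yl or pyridyl ring, or a short alkyl chain. Going by these compounds, the other places on the shared core also stay unchanged across these compounds, so the response to changes there is unknown.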